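This account rests on a few compounds, and the source may have more. Where it says the series, first, only, none or still open, it means among the compounds named here.

Compound 1 `O=C(N/N=C/c1ccc(Br)cc1)Nc1cccc2ccccc12`: 300 mg/kg
Compound 2 `CN(C)c1ccc(/C=N/NC(=O)Nc2cccc3ccccc23)cc1`: 100 mg/kg
Compound 3 `COc1cc(/C=N/NC(=O)Nc2cccc3ccccc23)cc(OC)c1OC`: 100 mg/kg

Of the compounds shown here, three built on a shared core have been tested in a functional assay on the whole organism (strain Swiss albino) with Mus musculus as the target, in the maximal electroshock model, with a stated time of 4 h; a higher number here means that more compound is needed for the effect, a lower number that less compound is needed. Compound 1 requires 300 mg/kg, compound 2 requires 100 mg/kg, and compound 3 requires 100 mg/kg. Compound 2 stands level with compound 3 at the digits recorded, and the two together hold the lowest numbers of the three, while compound 1 lies furthest away. For the measured compounds named here, the single one-place step measured so far, a 3.0-fold lower number from compound 1 to compound 2 (0.48 log units; beyond the scatter), is a modest one.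

Compound 4 `O=C(N/N=C/c1ccc([N+](=O)[O-])cc1)Nc1cccc2ccccc12` has not yet been measured. It differs from compound 2 in one place: nitro in place of dimethylamino on an aromatic carbon. Going by the values given here, the only measured step that touches this same group is the one from compound 1 to compound 2, which was modest and ran downward when dimethylamino replaced bromo. Nothing measured shows how nitro compares with either bromo or dimethylamino, so a partial return toward the number of compound 1 is as plausible as staying level with compound 2. For compound 4 a modest upward step, a 2.0-fold higher number from compound 2 to compound 4 (0.30 log units; within the scatter), is expected, and it may still fall inside the scatter. Compound 4 is therefore estimated at 200 mg/kg, with a range from 100 mg/kg to 300 mg/kg.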

Compound 4, minimum effective dose: 300 mg/kg
The estimate for compound 4 lay 1.5-fold (0.18 log units) below the measured number; measured number inside the range.
By their numbers in this assay, from the lowest: compounds 2 and 3 (each within the scatter of the next); then compounds 1 and 4 (each within the scatter of the next).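

At the aromatic carbon para to a large group, the change from dimethylamino to nitro gives a 3.0-fold higher number from compound 2 to compound 4 (0.48 log units; beyond the scatter) in this assay, which shows that the level reached with dimethylamino does not carry over to every replacement at this position. The change from bromo to nitro gives no change at the digits printed from compound 1 to compound 4 (within the scatter), so bromo and nitro cannot be told apart here, and among these three groups only dimethylamino, in compound 2, stands apart from the other two by a step beyond the scatter. Nothing measured here offers an explanation for this difference between the groups.

What the compounds shown leave open is whether dimethylamino is unusual at this position or whether other groups, such as a primary amine, a hydroxyl or a carboxylic acid, would also match compound 2 in this assay rather than compound 1 and compound 4. They also leave open whether the same order of these three groups would hold on a core other than the shared one, since all of these steps were read on that core alone.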